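Swapping phenyl for methoxy in compound 3

The source may hold more compounds than are shown below. What is called first, only, known or untested is meant among the compounds shown, and "the series" means these compounds.

In a functional assay on MDA-MB-231 cells (Homo sapiens) for cytotoxicity, read by MTT assay, with a stated time of 48 h (on this read-out higher numbers stand for weaker inhibition and lower numbers for stronger inhibition), compound 3 `COc1cc(-n2c(-c3ccc(-c4ccccc4)cc3)csc2=S)cc(OC)c1OC` gives > 100 ug/mL, which is a limit of the assay and not a number. Its two relatives differ at one place: compound 1 `COc1cc(-n2c(-c3ccc(Br)cc3)csc2=S)cc(OC)c1OC`, with bromo, gives 58 ug/mL, and compound 2 `COc1cc(-n2c(-c3ccc(C)cc3)csc2=S)cc(OC)c1OC`, with methyl, gives 11.8 ug/mL. Compound 4 `COc1ccc(-c2csc(=S)n2-c2cc(OC)c(OC)c(OC)c2)cc1` has methoxy in place of phenyl on an aromatic carbon.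

Going by the values given here, three measured steps bear on this change. Putting phenyl in place of methyl gave an at least 8.4-fold higher number from compound 2 to compound 3 (0.92 log units; beyond the scatter), and putting it in place of bromo gave an at least 1.7-fold higher number from compound 1 to compound 3 (0.23 log units; that floor lies within the scatter). Going from bromo to methyl gave a 4.9-fold lower number from compound 1 to compound 2 (0.69 log units; beyond the scatter), so the number moves clearly with the group at this place. Methoxy itself has not been measured here. Removing phenyl is therefore expected to give a lower number, probably between those of the bromo and methyl compounds, with a step of at least modest size.

The expected change is an at least 4.0-fold lower number from compound 3 to compound 4 (0.60 log units; beyond the scatter). For compound 4 the estimated value is 25 ug/mL, with an expected range from 8 ug/mL to 80 ug/mL.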

Compound 4, half-maximal inhibitory concentration: 53.8 ug/mL
Compound 4: middle estimate off by 2.2-fold (0.33 log units), on the low side; low and high end bracket the measured number.
By their numbers in this assay, from the lowest: compound 2; then compounds 4 and 1 (each within the scatter of the next). At a limit, above all of these: compound 3.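

Taking phenyl away does not by itself bring the number down to that of the methyl compound: in this assay methoxy in place of methyl gives a 4.6-fold higher number from compound 2 to compound 4 (0.66 log units; beyond the scatter) and so stays clearly apart from it. Methoxy and bromo, by contrast, cannot be told apart, with a 1.1-fold lower number from compound 1 to compound 4 (0.03 log units; within the scatter) as the step between them. As far as these compounds go, compound 3 gives a limit and not a number, so the change from phenyl to methoxy reads only as an at least 1.8-fold lower number from compound 3 to compound 4 (0.26 log units; that floor lies within the scatter) and its true size stays unknown: the limit of > 100 ug/mL in this assay, at which 1 of the 4 values shown sits.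

The compounds shown leave open whether methyl is a special case at this place or whether a longer chain such as ethyl would behave like it. They also leave open how an amine or a carboxylic acid here would compare with compound 2.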